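Replacing 3-(trifluoromethyl)phenyl with pyridin-3-yl on compound 2

The source may report more compounds than this note shows. Statements on the series, on what has been measured and on what is new or still open speak of the compounds shown alone.

Measured in an ADME assay on HepG2 2.2.15 cells (Homo sapiens) for cytotoxicity (on this read-out higher numbers stand for lower toxicity in this test and lower numbers for higher toxicity in this test), so far:
Compound 1 `O=C(OCCc1c(-c2ccccc2Cl)c2cc(Cl)ccc2[nH]c1=O)c1ccc([N+](=O)[O-])cc1` gives 1600000 nM
Compound 2 `O=C(/C=C/c1cccc(C(F)(F)F)c1)OCCc1c(-c2ccccc2Cl)c2cc(Cl)ccc2[nH]c1=O` gives > 1400000 nM (a limit)

Compound 2 reports > 1400000 nM as a limit of the measurement and not as a number. Compound 3 `O=C(/C=C/c1cccnc1)OCCc1c(-c2ccccc2Cl)c2cc(Cl)ccc2[nH]c1=O` carries pyridin-3-yl in place of 3-(trifluoromethyl)phenyl on a double-bonded chain carbon bound to a double-bonded chain carbon and is otherwise the same as compound 2. Within the data shown here, one measured step bears on this change: a step that the limit leaves unreadable from compound 1 to compound 2 also alters the group on the carbonyl carbon. Its size cannot be read because of the limit of > 1400000 nM in this assay, at which 1 of the 2 values shown sits, and so it offers no measure for the new change. Among the measured compounds shown here, compound 1 gives the only true number, 1600000 nM in this assay and the expectation rests on it. No step beyond the usual scatter is expected, in neither direction, so the expected step that the limit leaves unreadable from compound 2 to compound 3 is small. Compound 3 is estimated at 1500000 nM with an expected range of 700000 nM to 2500000 nM and it may also return only a limit.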

Compound 3, half-maximal cytotoxic concentration: 39000 nM
Compound 3: middle estimate off by 38-fold (1.59 log units), on the high side; measured number outside the range, below it.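

In this assay, among these compounds, the place on the double-bonded chain carbon proves able to move the read-out: pyridin-3-yl in place of 3-(trifluoromethyl)phenyl gives an at least 35-fold lower number from compound 2 to compound 3 (1.55 log units; beyond the scatter), the first readable step at this place. That step is bounded from one side only, since the value of compound 2 is a limit and not a number: the limit of > 1400000 nM in this assay, at which 1 of the 3 values shown sits. Among the compounds shown here, the comparison with the one true earlier number points the same way, with 2-(pyridin-3-yl)ethenyl in place of 4-nitrophenyl on a carbonyl carbon giving a 41-fold lower number from compound 1 to compound 3 (1.61 log units; beyond the scatter).

The compounds shown leave open whether the ring nitrogen of pyridin-3-yl is what matters, and an unsubstituted phenyl or a pyridin-4-yl at the same place would bear on that. They also leave open how an amine or a carboxylic acid on this ring would read.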